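Trimming a methoxy group from the cinnamamide aryl ring

This account rests on a few compounds, and the source may have more. Where it says the series, first, only, none or still open, it means among the compounds named here.

Measured compounds in a functional assay on B16 cells (Mus musculus) for cytotoxicity, read by MTT assay, with a stated time of 72 h; on this read-out higher numbers stand for weaker inhibition and lower numbers for stronger inhibition:
Compound 1, `COc1ccc(C(=O)c2cc(OC)c(OC)c(OC)c2)cc1NC(=O)/C=C/c1cc(OC)c(OC)c(OC)c1`: 1200 nM
Compound 2, `COc1ccc(C(=O)c2cc(OC)c(OC)c(OC)c2)cc1NC(=O)/C=C/c1ccc(F)cc1`: 400 nM
Compound 3, `COc1cc(C(=O)c2cc(OC)c(OC)c(OC)c2)cc(NC(=O)/C=C/c2cc(OC)c(OC)c(OC)c2)c1OC`: 2500 nM

Among these three, compound 3 gives the highest number, meaning the weakest inhibition; its nearest neighbour is compound 1, and compound 2 sits furthest away with the lowest number.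

The next compound, compound 4, is `COc1ccc(/C=C/C(=O)Nc2cc(C(=O)c3cc(OC)c(OC)c(OC)c3)cc(OC)c2OC)cc1OC`. Compared with compound 3 the change is hydrogen in place of methoxy on an aromatic carbon. Going by the values given here, two measured steps bear on this. The step of a 3.0-fold lower number from compound 1 to compound 2 (0.48 log units; beyond the scatter) shows that exchanging the 3,4,5-trimethoxyphenyl on the double-bonded chain for a different, smaller aryl group lowered the number. The step of a 2.1-fold higher number from compound 1 to compound 3 (0.32 log units; beyond the scatter) shows that adding a methoxy to the core raised it. Compound 4 removes one methoxy from the same aryl ring that was exchanged in the first of these steps, so a modest lowering of the number in this assay is expected, though removal of a single methoxy is a smaller change than the full exchange, and the benefit may be partly lost to scatter.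

On this basis compound 4 is expected to give 1500 nM in this assay, with a range from 600 nM to 4000 nM, an expected step of a 1.7-fold lower number from compound 3 to compound 4 (0.22 log units; within the scatter).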

Compound 4, half-maximal inhibitory concentration: 1300 nM
Compound 4: middle estimate off by 1.2-fold (0.06 log units), on the high side; measured number inside the range.
By their numbers in this assay, from the lowest: compound 2; then compounds 1, 4 and 3 (each within the scatter of the next, the first and the last beyond it).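

Removing one methoxy from the 3,4,5-trimethoxyphenyl ring of compound 3 leaves a 3,4-dimethoxyphenyl ring and gives, in this assay, a 1.9-fold lower number from compound 3 to compound 4 (0.28 log units; within the scatter), so this methoxy, taken alone on this core, has no effect that can be told apart from ordinary assay variation. The earlier step, a 3.0-fold lower number from compound 1 to compound 2 (0.48 log units; beyond the scatter), replaced the whole aryl group on the core of compound 1 and so could not show what a single methoxy on this ring contributes; the new pair isolates that one group and shows that the ring tolerates its loss in this assay. No supporting measurement is available to explain this result.

The compounds shown leave open whether a hydroxyl group or an amine on this same aromatic carbon would shift the number beyond the scatter, since hydrogen is the only replacement for this methoxy here. They also leave open whether the 4-fluorophenyl group of compound 2 would give a lower number on the core of compound 3, and whether removing a further methoxy from the ring of compound 4 would change the result.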